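Trifluoromethyl in Place of Chloro: Compound 3 Awaits Measurement

The compounds below may be only part of what the source reports. "The series", "measured", "known", "first", "only" and "open" are said of these compounds alone.

Going by the values given here, compound 1 `O=C(N[C@@H](CO)c1cccc(Cl)c1)[C@H]1CC(F)(F)CC[C@@H]1c1ccccc1` is the more potent of the two compounds measured so far in an assay for activation of potassium voltage-gated channel subfamily KQT member 4 (Homo sapiens), read by patch clamp; on this read-out higher numbers stand for an effect only at larger amounts of compound and lower numbers for an effect already at smaller amounts. In this assay compound 1 gives 100 nM, while compound 2 `C[C@H](NC(=O)[C@H]1CC(F)(F)CC[C@@H]1c1ccccc1)c1ccccc1` gives 4000 nM, a gap well beyond the usual scatter, so compound 1 stands at the low end of the numbers seen. Compound 3 `O=C(N[C@@H](CO)c1cccc(C(F)(F)F)c1)[C@H]1CC(F)(F)CC[C@@H]1c1ccccc1` has not yet been measured. It differs from compound 1 in one place: trifluoromethyl in place of chloro on an aromatic carbon. Among the compounds with values here, no pair of measured compounds differs by this change alone, so the data give no direct guide to its size. The step is expected to be small, within the scatter, with no clear direction; the estimated step is a 1.5-fold higher number from compound 1 to compound 3 (0.18 log units; within the scatter). Compound 3 is therefore expected to give about 150 nM, within a range from 40 nM to 600 nM.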

Compound 3, half-maximal effective concentration: 20 nM
Compound 3: middle estimate off by 7.5-fold (0.88 log units), on the high side; measured number outside the range, below it.
By their numbers in this assay, from the lowest: compound 3; then compound 1; then compound 2.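

In this assay, replacing chloro with trifluoromethyl on this aromatic carbon gives a 5.0-fold lower number from compound 1 to compound 3 (0.70 log units; beyond the scatter), which shows that the number responds to the group held at this place, meta to a large group. Going by these compounds alone, this is the first step that can be read for a single change, and it goes toward lower numbers, an effect at smaller amounts of compound. The change brings more heavy atoms but no hydrogen-bond donors or acceptors, and no measurement available here explains the step.

The compounds shown leave open whether other groups at this place, such as a nitrile, a methoxy group or bromo, would give a similar step. They also leave open whether trifluoromethyl at another carbon of this ring would have the same effect.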